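A few compounds are considered here, and "the series" means these few. Any claim that something is new, unique, unknown or untested is made for them only; others in the source may bear on it.

Working notes on a small set of aryl ketones assessed in a functional assay on DU-145 cells (Homo sapiens) for inhibition, read by trypan blue exclusion, with a stated time of 96 h; on this read-out higher numbers stand for weaker inhibition of growth and lower numbers for stronger inhibition of growth.

Compound 2 `O=C(/C(=C\c1c(O)cc(O)cc1O)S(=O)(=O)c1ccccc1Br)c1ccc(Cl)cc1` carries a trihydroxyphenyl group on the alkene together with a sulfonyl substituent, and in this assay compound 2 gives 50000 nM. Compound 1 `O=C(/C(=C\c1c(O)cc(O)cc1O)S(=O)(=O)c1ccccc1Br)c1ccc(Br)cc1` is the same core with one halogen exchanged; the difference is bromo in place of chloro on an aromatic carbon. In this assay compound 1 gives 50000 nM. The step of no change at the digits printed from compound 2 to compound 1 (within the scatter) therefore shows the halogen swap leaving the read-out where it was.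

Compound 3 `CSc1ccc(/C=C(/SCc2ccc(C)cc2)C(=O)c2ccc(Cl)cc2)cc1` belongs to a second core, bearing a methylthio group on the alkene-linked ring and a benzylthio group in place of the sulfonyl; how its core differs from that of compound 2 is not broken down here. In this assay compound 3 gives 25000 nM, which sits within the scatter of both compound 1 and compound 2.

Compound 4 `CSc1ccc(/C=C(/SCc2ccc(C)cc2)C(=O)c2ccc(Br)cc2)cc1` is not yet measured. It differs from compound 3 by bromo in place of chloro on an aromatic carbon. The place of this change and the place of the change from compound 2 to compound 1 read the same word for word, so compound 3 to compound 4 is the same change made on the second core. Because no change at the digits printed from compound 2 to compound 1 (within the scatter) lay within the scatter on the first core, the expectation is that the step from compound 3 to compound 4 will also be flat, estimated as no change at the digits printed from compound 3 to compound 4 (within the scatter). Compound 4 is accordingly expected to give about 25000 nM in this assay, with an estimated range from 12000 nM to 50000 nM; the read-out for compound 4 follows.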

Compound 4, concentration for 50% growth inhibition: > 100000 nM
Compound 4 was reported as a limit (the forecaster's own chance of this, stated with the estimate: 20%); middle value at least 4.0-fold (0.60 log units) away from the limit.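

In this assay, bromo in place of chloro on the core of compound 3 gives an at least 4.0-fold higher number from compound 3 to compound 4 (0.60 log units; beyond the scatter), and this step does not match the one seen for the same change on the core of compound 1: the same change on two cores in this assay, no change at the digits printed (within the scatter) from compound 2 to compound 1 and an at least 4.0-fold higher number (0.60 log units; beyond the scatter) from compound 3 to compound 4, at least 4.0-fold (0.60 log units) apart, beyond the scatter of two such steps. Compound 4 gives > 100000 nM, which is a limit of the assay and not a number: the limit of > 100000 nM in this assay, at which 1 of the 4 values shown sits. The flat result on the core of compound 1 therefore does not carry over to the core of compound 3, but with one matched pair on each core this shows only that the outcome of the swap differs between these two cores, not which of the several differences between the cores goes with that outcome, nor how large the step from compound 3 to compound 4 really is.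

The compounds shown leave open how a fluoro group or an amine in the same place on the 4-halophenyl ketone would read on either core, as only chloro and bromo appear there. They also leave open how the swap would read on a core that differs from the core of compound 3 in one place only, such as one with a sulfonyl in place of the benzylthio group.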